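Moving the Imidazole Substituents: From Compound 2 to Compound 3

The compounds below may be only part of what the source reports. "The series", "measured", "known", "first", "only" and "open" are said of these compounds alone.

Measured so far:
- compound 1, `CC(C)(C)NCCC(c1ccccc1)c1ccccc1`: 792 nM
- compound 2, `CCCc1nccn1CCC(C(N)=O)(c1ccccc1)c1ccccc1`: 177 nM

In an assay on ileum with muscarinic acetylcholine receptor M3 (Cavia porcellus) as the target (on this read-out higher numbers stand for weaker inhibition and lower numbers for stronger inhibition), compound 2 gives the lower of the two numbers, and its gap to compound 1 is beyond the usual scatter. Compound 3, `CCc1ncn(CCC(C(N)=O)(c2ccccc2)c2ccccc2)c1CC`, is not yet measured. It differs from compound 2 by 4,5-diethyl-1H-imidazol-1-yl in place of 2-propyl-1H-imidazol-1-yl on a saturated chain carbon, three bonds along the chain from two aromatic carbons and a carbonyl carbon. Among the compounds with values here, no pair of measured compounds shows what this exchange does, so only a modest step, if any, is expected in this assay, possibly toward a higher number. Compound 3 is expected to give 300 nM, within 80 nM to 1200 nM, an estimated step of a 1.7-fold higher number from compound 2 to compound 3 (0.23 log units; within the scatter).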

Compound 3, antagonist equilibrium constant: 3.98 nM
Compound 3: the middle estimate sits 75-fold (1.88 log units) above what was measured, outside the stated range (below it).
By their numbers in this assay, from the lowest: compound 3; then compound 2; then compound 1.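

In this assay the exchange of 2-propyl-1H-imidazol-1-yl for 4,5-diethyl-1H-imidazol-1-yl brings a 44-fold lower number from compound 2 to compound 3 (1.65 log units; beyond the scatter) and so marks this group as a highly sensitive place in the molecule. The ring type is unchanged and the group gains only one carbon, so a small change in how the carbon chains sit on the ring can carry a large step. Nothing measured here explains why. The compounds shown leave open whether a single ethyl group would be enough. They also leave open how methyl groups or longer butyl chains on the ring would compare.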